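The compounds below may be only part of what the source reports. "The series", "measured", "known", "first", "only" and "open" are said of these compounds alone.

Series notes. The shared core carries a chloro on the aromatic carbon of compound 1 `O=C1C(=O)N(CN2CCN(c3ccnc4cc(Cl)ccc34)CC2)c2cc(Cl)ccc21` and a bromo at the same place in compound 2 `O=C1C(=O)N(CN2CCN(c3ccnc4cc(Cl)ccc34)CC2)c2cc(Br)ccc21`; the change is bromo in place of chloro on an aromatic carbon. In an ADME assay on 184B5 cells (Homo sapiens) for cytotoxicity, read by sulforhodamine B assay, with a stated time of 48 h (a higher number here means a weaker inhibitor of growth, a lower number a stronger inhibitor of growth), compound 1 gives 47500 nM, and compound 2 gives 33200 nM, so the step is a 1.4-fold lower number from compound 1 to compound 2 (0.16 log units; within the scatter).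

Compound 3 `O=C1C(=O)N(CN2CCN(c3ccnc4cc(C(F)(F)F)ccc34)CC2)c2cccc(Cl)c21` stands on a different core, and the difference between the two cores is not broken down here. In this assay compound 3 gives 47400 nM, close to compound 1 and to compound 2.

Compound 4 `O=C1C(=O)N(CN2CCN(c3ccnc4cc(C(F)(F)F)ccc34)CC2)c2cccc(Br)c21` is not yet measured. It relates to compound 3 by bromo in place of chloro on an aromatic carbon, the same kind of change as from compound 1 to compound 2, though the place differs: there the halogen sits meta to a fused ring and para to a fused ring, here ortho to a fused ring and meta to a fused ring. The step from compound 3 to compound 4 is expected to be a 1.3-fold lower number from compound 3 to compound 4 (0.12 log units; within the scatter), resting on a 1.4-fold lower number from compound 1 to compound 2 (0.16 log units; within the scatter) and on compound 3 at 47400 nM. Compound 4 is therefore estimated at 36000 nM, with a range from 18000 nM to 72000 nM.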

Compound 4, concentration for 50% growth inhibition: 49700 nM
Compound 4: the middle estimate sits 1.4-fold (0.14 log units) below what was measured, and the stated range covers the measured number.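

Bromo in place of chloro gives a 1.0-fold higher number from compound 3 to compound 4 (0.02 log units; within the scatter) in this assay and, set beside the earlier step, agrees with it: the same change on two cores in this assay, a 1.4-fold lower number (0.16 log units; within the scatter) from compound 1 to compound 2 and a 1.0-fold higher number (0.02 log units; within the scatter) from compound 3 to compound 4, 1.5-fold (0.18 log units) apart, within the scatter of two such steps

On these two cores the exchange therefore carries over as a step within the scatter, even though the halogen's place differs between the two pairs. This does not show that the exchange has any real effect on growth inhibition, and with core and place differing together, the contribution of either cannot be separated. Two pairs also give no rule for any other core in the series.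

The compounds shown carry only chloro or bromo at these places, so what an amine, a carboxylic acid or a longer chain would do there in this assay stays open. Also open, going by these compounds, is whether any change at these places can produce a step beyond the scatter on either core.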